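The compounds below may be only part of what the source reports. "The series", "measured", "known", "first", "only" and "open" are said of these compounds alone.

Measured so far:
- compound 1, `Cc1nn(-c2nc(-c3ccc(Cl)c(Cl)c3)c(SC(C)C)s2)c(C(=O)O)c1-c1ccccc1[N+](=O)[O-]`: 4700 nM
- compound 2, `Cc1nn(-c2nc(-c3ccc(Cl)c(Cl)c3)c(SC(C)C)s2)c(C(=O)O)c1-c1cc(C(F)(F)F)cc(C(F)(F)F)c1`: 1800 nM

Two compounds of the shared core have numbers in a functional assay on BJAB cells (Homo sapiens) for antiproliferative activity, with a stated time of 4 days; a lower number here means that less compound is needed, a higher number that more compound is needed for the effect. Compound 1 gives the higher of the two; compound 2 gives the lower, and the gap between them lies beyond the scatter. Nothing more is known of the series than these two values, so the weight of any single group on the phenyl ring attached to the core cannot be read off from a measured step.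

Compound 3, `Cc1nn(-c2nc(-c3ccc(Cl)c(Cl)c3)c(SC(C)C)s2)c(C(=O)O)c1-c1ccccc1`, has not been measured in this assay. It differs from compound 1 in one place: hydrogen in place of nitro on an aromatic carbon. Among the measured compounds shown here, the phenyl ring thus carries no substituent at all, which no measured compound shows. Compound 2, which carries two trifluoromethyl groups, sits lower than compound 1, but that comparison involves a different group at a different place and carries no direct information on the loss of the nitro group.

For the measured compounds named here, with no step of this kind on record, the step from compound 1 to compound 3 is expected to be small, within or near the scatter, with a slight lean toward a higher number: a 1.2-fold higher number from compound 1 to compound 3 (0.07 log units; within the scatter). Compound 3 is therefore estimated at 5500 nM, with a range from 2000 nM to 15000 nM.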

Compound 3, half-maximal effective concentration: 3000 nM
For compound 3 the middle estimate is 1.8-fold (0.26 log units) above the measured one; measured number inside the range.
By their numbers in this assay, from the lowest: compounds 2, 3 and 1 (each within the scatter of the next, the first and the last beyond it).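

In this assay, among the compounds shown here, the change from 2-nitrophenyl to phenyl gives a 1.6-fold lower number from compound 1 to compound 3 (0.19 log units; within the scatter), the first step that can be read at this position on the shared core. Loss of the nitro group, ortho to a large group, leaves compound 3 at 3000 nM, within the scatter of compound 1, so at this place in these two compounds the nitro group is not required for a number of this size, and the unsubstituted phenyl ring serves as a reference point for this position. No measurement of any property of these compounds bears on this step, so it stands without an explanation.

For the compounds shown here, whether a different group on the same aromatic carbon, such as an amine or a methoxy group, would shift the number beyond the scatter remains open, as only one step has been read at this position. Also open, going by these compounds, is whether hydrogen in place of nitro would give a similarly small step on a compound in which the carboxylic acid of the shared core is replaced by an amide.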